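This account rests on a few compounds, and the source may have more. Where it says the series, first, only, none or still open, it means among the compounds named here.

Compound 1 `O=S(=O)(Nc1ccc(Cl)cc1)c1ccc(Cl)cc1` carries the shared core of this set. In a physicochemical assay for acid dissociation, compound 1 gives 8.3. Compound 2 `O=S(=O)(Nc1ccc(Cl)cc1)c1ccc(Br)cc1` differs from it by bromo in place of chloro on an aromatic carbon, and in this assay compound 2 gives 8.24, a step of a number 0.06 log units lower from compound 1 to compound 2 (within the scatter). Compound 3 `O=S(=O)(Nc1ccc(F)cc1)c1ccc(Cl)cc1` differs from compound 1 by fluoro in place of chloro on an aromatic carbon; in this assay compound 3 gives 8.41, a step of a number 0.11 log units higher from compound 1 to compound 3 (within the scatter). Compound 4 `O=S(=O)(Nc1ccc(F)cc1)c1ccc(Br)cc1` has not yet been measured. It differs from compound 3 by bromo in place of chloro on an aromatic carbon, the same change that was made from compound 1 to compound 2, at the same place in both pairs. The step is expected to be a number 0.06 log units lower from compound 3 to compound 4 (within the scatter), because a number 0.06 log units lower from compound 1 to compound 2 (within the scatter) in the earlier pair. Compound 4 is therefore estimated to give 8.35 in this assay, with a likely range from 8.15 to 8.55.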

Compound 4, acid dissociation constant: 8.38
The estimate for compound 4 lay 0.03 log units below the measured number, and the stated range covers the measured number.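

In this assay, bromo in place of chloro on an aromatic carbon gives a small step on the fluoro-bearing core (a number 0.03 log units lower from compound 3 to compound 4 (within the scatter)), and the same change on the core of compound 1 gave a similarly small one (a number 0.06 log units lower from compound 1 to compound 2 (within the scatter)). Fluoro in place of chloro also stays small (a number 0.14 log units higher from compound 2 to compound 4 (within the scatter)). This shows that the swap had no readable effect on either core, but with both steps inside the scatter it does not show that a real effect carries from one core to the other, and no measurement here bears on the reason.

The compounds shown carry only fluoro, chloro and bromo at these places. On these data alone, how a nitrile or a methoxy group would behave there remains open.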